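A Larger Group on the Ring Nitrogen of Compound 2

The source may hold more compounds than are shown below. What is called first, only, known or untested is meant among the compounds shown, and "the series" means these compounds.

Compound 1 `CNc1nc(SCc2nc3ccccc3[nH]2)nc(-c2ccccc2)c1C#N`: 13.2 nM
Compound 2 `CCNc1nc(SCc2nc3ccccc3[nH]2)nc(-c2ccccc2)c1C#N`: 4.38 nM

Within the data shown here, in a functional assay on K562 cells (Homo sapiens) for cytotoxicity, read by MTT assay, with a stated time of 3 days (a higher number here means a weaker inhibitor, a lower number a stronger inhibitor), compound 2 has the lowest of the two numbers, the only measured step being a 3.0-fold lower number from compound 1 to compound 2 (0.48 log units; beyond the scatter). Compound 3 `N#Cc1c(NNC(N)=S)nc(SCc2nc3ccccc3[nH]2)nc1-c1ccccc1` differs from compound 2 by a group of 4 heavy atoms (1 carbon, 2 nitrogen, 1 sulfur; no ring) in place of a group of 2 heavy atoms (2 carbon; no ring), on a nitrogen on an aromatic ring. The measured step concerned a small change at the same nitrogen and says little about this much larger exchange, so no direction can be read from it with confidence. Compound 3 is therefore estimated at 20 nM, within a wide range from 3 nM to 150 nM, which would mean an expected 4.6-fold higher number from compound 2 to compound 3 (0.66 log units; beyond the scatter).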

Compound 3, half-maximal inhibitory concentration: 8.9 nM
Compound 3: middle estimate off by 2.2-fold (0.35 log units), on the high side; measured number inside the range.
By their numbers in this assay, from the lowest: compound 2; then compounds 3 and 1 (each within the scatter of the next).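

At this nitrogen on an aromatic ring, the core still gives a low number with far more than a short chain. In this assay, ethyl giving way to the group of 4 heavy atoms, with its 2 hydrogen-bond donors, brings a 2.0-fold higher number from compound 2 to compound 3 (0.31 log units; beyond the scatter), a modest loss. Measured against the single carbon atom, the same group gives a 1.5-fold lower number from compound 1 to compound 3 (0.17 log units; within the scatter), so those two compounds cannot be told apart. Nothing measured here explains either step. From the compounds shown here alone, what a longer chain such as propyl or a phenyl ring would do at this nitrogen stays open.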